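Trifluoromethoxy to methoxy: a step without a precedent

A few compounds are considered here, and "the series" means these few. Any claim that something is new, unique, unknown or untested is made for them only; others in the source may bear on it.

Measured compounds:
compound 1 `O=C(O)CCc1ccc2[nH]c(-c3ccccc3C(F)(F)F)cc2c1` gives 1310 nM in a functional assay on CHO cells for agonist activity at Free fatty acid receptor 1 (Homo sapiens), read by a luciferase reporter, with a stated time of 24 h; a lower number here means that less compound is needed, a higher number that more compound is needed for the effect
compound 2 `O=C(O)CCc1ccc2[nH]c(-c3ccccc3OC(F)(F)F)cc2c1` gives 1020 nM in this assay

Of the compounds shown here, two have been measured in this assay, and they sit close together. For the measured compounds named here, the single step between them, a 1.3-fold lower number from compound 1 to compound 2 (0.11 log units; within the scatter), lies within the scatter, so compound 2 and compound 1 cannot be told apart on these numbers; compound 2 simply stands beside compound 1.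

Compound 3 `COc1ccccc1-c1cc2cc(CCC(=O)O)ccc2[nH]1` has not yet been measured. It differs from compound 2 by methyl in place of trifluoromethyl on an oxygen on an aromatic ring. Going by the values given here, the one step that has been measured, from a trifluoromethyl to a trifluoromethoxy group, is a different change and was within the scatter; no measured step exchanges a trifluoromethyl for a methyl on an oxygen, so there is no direct precedent for the step in this assay.

With nothing pointing in either direction, the expectation for compound 3 is a number close to that of compound 2, a step of a 1.2-fold higher number from compound 2 to compound 3 (0.07 log units; within the scatter) that is not expected to go beyond the scatter, with a wide range to allow for the untested change. Compound 3 is therefore estimated at 1200 nM, between 400 nM and 4000 nM.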

Compound 3, half-maximal effective concentration: > 25 nM
Compound 3: a limit, no number; the forecaster's own chance of this, stated with the estimate: 10%; the middle value lies beyond the limit too.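

In this assay compound 3 gives > 25 nM, which is a limit of the assay and not a number. The steps to compound 3 from compound 2 and from compound 1 therefore cannot be read. The compounds shown leave open whether the actual number for compound 3 stands close to those of compound 1 and compound 2 or apart from them.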